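This account rests on a few compounds, and the source may have more. Where it says the series, first, only, none or still open, it means among the compounds named here.

Measured in a functional assay on HeLa cells (Homo sapiens) for inhibition, read by MTT assay, with a stated time of 72 h; on this read-out higher numbers stand for weaker inhibition and lower numbers for stronger inhibition:
- compound 1 `COc1ccc(-c2nnc(SCCCN3CCN(c4nc5ccccc5o4)CC3)o2)cc1`: 210000 nM
- compound 2 `O=[N+]([O-])c1ccc(-c2nnc(SCCCN3CCN(c4nc5ccccc5o4)CC3)o2)cc1`: 114000 nM

For the measured compounds named here, compound 2, at 114000 nM, has the lower of the two numbers, but the gap to its only neighbour lies within the scatter, so the pair cannot be ranked. The next compound, compound 3 `Cc1ccc(-c2nnc(SCCCN3CCN(c4nc5ccccc5o4)CC3)o2)cc1`, has methyl in place of nitro on an aromatic carbon, para to a large group (methyl in place of nitro on an aromatic carbon).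

Going by the values given here, one measured step bears on this change: a 1.8-fold lower number from compound 1 to compound 2 (0.27 log units; within the scatter), with nitro in place of methoxy. On that evidence, no step beyond the scatter is expected in this assay, and no firm direction can be drawn. The expected change is a 1.3-fold higher number from compound 2 to compound 3 (0.12 log units; within the scatter). For compound 3 the estimated value is 150000 nM, with an expected range of 70000 nM to 320000 nM.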

Compound 3, half-maximal inhibitory concentration: 133000 nM
Beside the measured number, compound 3's estimate is 1.1-fold (0.05 log units) above it; low and high end bracket the measured number.
By their numbers in this assay, from the lowest: compounds 2, 3 and 1 (each within the scatter of the next).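

In this assay, methyl in place of nitro on the aromatic carbon para to a large group gives a 1.2-fold higher number from compound 2 to compound 3 (0.07 log units; within the scatter), and methyl in place of methoxy at the same carbon gives a 1.6-fold lower number from compound 1 to compound 3 (0.20 log units; within the scatter). With a third group at this position, every listed step among the three compounds lies within the scatter, so nitro, methoxy and methyl cannot be ranked here, and the 4-nitrophenyl and 4-methylphenyl forms cannot be told apart. No available evidence bears on this result. As far as these compounds go, whether an amine or a carboxylic acid on this aromatic carbon would move the number beyond the scatter remains open. From the compounds shown here alone, it also remains open whether a change elsewhere in the shared core, such as a longer chain, would do so.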